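Swapping chloro for bromo in a series at its limit

The compounds below may be only part of what the source reports. "The series", "measured", "known", "first", "only" and "open" are said of these compounds alone.

Three compounds share one core and differ in a single group on an aromatic carbon: compound 1 (`COc1ccc(Cn2c(Cl)nc3cc(Cl)c(Cl)cc32)cc1`) carries methoxy, compound 2 (`CC(C)(C)c1ccc(Cn2c(Cl)nc3cc(Cl)c(Cl)cc32)cc1`) tert-butyl and compound 3 (`FC(F)(F)c1ccc(Cn2c(Cl)nc3cc(Cl)c(Cl)cc32)cc1`) trifluoromethyl. In a functional assay on KB cells (Homo sapiens) for inhibition (on this read-out higher numbers stand for weaker inhibition and lower numbers for stronger inhibition), compound 1 gives > 100000 nM, which is a limit and not a number. Compound 2 gives > 100000 nM, also a limit. Compound 3 gives > 100000 nM, again a limit. Compound 3 therefore has no number of its own and stands with the other two at the limit of > 100000 nM in this assay, at which 3 of the 3 values shown sit.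

Compound 4 (`FC(F)(F)c1ccc(Cn2c(Br)nc3cc(Cl)c(Cl)cc32)cc1`) keeps everything in compound 3 except one group: bromo in place of chloro on an aromatic carbon. The bromo sits on an aromatic carbon between two ring nitrogen atoms. The measured steps offer little guidance. Neither a step that the two limits leave unreadable from compound 1 to compound 3 nor a step that the two limits leave unreadable from compound 2 to compound 3 has a readable size, and the same holds for a step that the two limits leave unreadable from compound 1 to compound 2. None of them touches the chloro group. No step beyond the scatter is therefore expected in this assay, in either direction, and compound 4 will most likely also reach the limit. The expected change is a number no higher from compound 3 to compound 4 (the limit leaves the size open). For compound 4 the estimated value is 100000 nM, with an expected range from 40000 nM to 250000 nM.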

Compound 4, half-maximal inhibitory concentration: > 100000 nM
Compound 4: only a limit was reported; the forecaster's own chance of this, stated with the estimate: 85%; the middle value sits exactly at the limit.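

The swap of chloro for bromo from compound 3 to compound 4 has no readable size, because both values are limits and not numbers, as for every compound here: the limit of > 100000 nM in this assay, at which 4 of the 4 values shown sit.

The compounds shown leave open how strongly any of them inhibits in this assay, and whether bromo and chloro differ there at all.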